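Anilino Swap on a Shared Core: Methyl to Fluorine

The source may hold more compounds than are shown below. What is called first, only, known or untested is meant among the compounds shown, and "the series" means these compounds.

Compound 1 `Cc1ccc(NC2=CC(=O)c3c(nc4n3[C@H]3OC[C@@H](O)[C@H]3OC4)C2=O)cc1` carries a 4-methylphenyl group on the amine nitrogen of the shared core. In a functional assay on HeLa cells (Homo sapiens) for inhibition, read by sulforhodamine B assay (on this read-out higher numbers stand for weaker inhibition and lower numbers for stronger inhibition), compound 1 gives 6590 nM, the higher of the two numbers recorded as values. Compound 2 `CCOc1ccccc1NC1=CC(=O)c2nc3n(c2C1=O)[C@H]1OC[C@@H](O)[C@H]1OC3` bears a different aryl group at the same position; in this assay compound 2 gives 6040 nM, a number within the scatter of that of compound 1. Compound 3 `CCCN(CCC)C1=CC(=O)c2nc3n(c2C1=O)[C@H]1OC[C@@H](O)[C@H]1OC3` has no aryl group on that nitrogen. In this assay compound 3 reaches only > 16000 nM, which is a limit of the assay and not a number, so compound 3 sits at the limit of > 16000 nM in this assay, at which 1 of the 3 values shown sits.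

Compound 4 `O=C1C(Nc2cccc(F)c2)=CC(=O)c2c1nc1n2[C@H]2OC[C@@H](O)[C@H]2OC1` has not yet been measured. It differs from compound 1 as follows: 3-fluorophenyl in place of 4-methylphenyl on an amine nitrogen. Going by the values given here, no step between measured compounds isolates this change, so the expectation rests on compound 1 and compound 2 alone, whose numbers in this assay lie close together. The step from compound 1 to compound 4 is expected to be small, a 1.1-fold higher number from compound 1 to compound 4 (0.03 log units; within the scatter), and not beyond the scatter. Compound 4 is estimated at 7000 nM, within a range from 3000 nM to 16000 nM.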

Compound 4, half-maximal inhibitory concentration: > 8000 nM
Compound 4 was reported as a limit; the forecaster's own chance of this, stated with the estimate: 20%; middle value at least 1.1-fold (0.05 log units) away from the limit.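

Compound 4 is reported only as a limit of the assay, not as a number: the limit of > 8000 nM in this assay, at which 1 of the 4 values shown sits.

The swap to 3-fluorophenyl from 4-methylphenyl on an amine nitrogen can therefore be read only as an at least 1.2-fold higher number from compound 1 to compound 4 (0.08 log units; that floor lies within the scatter), a floor that leaves the real size of the step unknown. An aryl group on that nitrogen also no longer goes with a measured number in every case: compound 1 and compound 2 carry one and give numbers, whereas compound 4 carries one and gives a limit.

The compounds shown do not separate the loss of the methyl group from the arrival of the fluorine, nor do they tell whether compound 4 truly parts from compound 1 beyond the scatter. From the compounds shown here alone, how a phenyl ring bearing a chlorine, a methoxy group or a carboxylic acid would read in this assay stays open.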